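Swapping cyclopropyl for propyl on compound 3

The source may hold more compounds than are shown below. What is called first, only, known or untested is meant among the compounds shown, and "the series" means these compounds.

Values in a functional assay on MCF7 cells (Homo sapiens) for cytotoxicity, read by MTT assay, with a stated time of 72 h; a lower number here means a stronger inhibitor, a higher number a weaker inhibitor:
compound 1 `COc1ncc(-c2ccc3nc(NC(=O)N(C)C)nn3c2)cc1NS(=O)(=O)c1ccc(F)cc1`: 1560 nM
compound 2 `COc1ncc(-c2ccc3nc(NC(=O)NCCN4CCCC4)nn3c2)cc1NS(=O)(=O)c1ccc(F)cc1`: 380 nM
compound 3 `COc1ncc(-c2ccc3nc(NC(=O)NC4CC4)nn3c2)cc1NS(=O)(=O)c1ccc(F)cc1`: 300 nM

Compound 3 stands well clear of one neighbour, with a 5.2-fold lower number from compound 1 to compound 3 (0.72 log units; beyond the scatter), but not of the other, with a 1.3-fold lower number from compound 2 to compound 3 (0.10 log units; within the scatter). Compound 4 `CCCNC(=O)Nc1nc2ccc(-c3cnc(OC)c(NS(=O)(=O)c4ccc(F)cc4)c3)cn2n1` differs from compound 3 in a single place: propyl in place of cyclopropyl on an amide-type nitrogen. This puts propyl in place of cyclopropyl on an amide-type nitrogen.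

Within the data shown here, no measured step makes exactly this change, so the evidence is indirect. Two steps away from dimethylamino were modest and beyond the scatter: a 4.1-fold lower number from compound 1 to compound 2 (0.61 log units; beyond the scatter), alongside the one already given for cyclopropylamino. The step that best fits the question compares two quite different groups on that same nitrogen, and it gave only a 1.3-fold lower number from compound 2 to compound 3 (0.10 log units; within the scatter). Swapping cyclopropyl for propyl is a smaller change than that one, so no shift beyond the scatter is expected in this assay. The expected step is a 1.2-fold higher number from compound 3 to compound 4 (0.07 log units; within the scatter). The estimate for compound 4 is 350 nM, with an expected range of 150 nM to 800 nM.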

Compound 4, half-maximal inhibitory concentration: 360 nM
Compound 4: middle estimate off by 1.0-fold (0.01 log units), on the low side; the range from low to high includes it.
By their numbers in this assay, from the lowest: compounds 3, 4 and 2 (each within the scatter of the next); then compound 1.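

In this assay opening the three-membered ring of cyclopropyl into a propyl chain with the same carbon count leaves the result within the scatter (a 1.2-fold higher number from compound 3 to compound 4 (0.08 log units; within the scatter)), so at this amide-type nitrogen the closed ring is not required to keep the number. Propyl also sits within the scatter of the 2-(pyrrolidin-1-yl)ethyl group (a 1.1-fold lower number from compound 2 to compound 4 (0.02 log units; within the scatter)), while the step away from dimethylamino lies beyond it (a 4.3-fold lower number from compound 1 to compound 4 (0.64 log units; beyond the scatter)), which leaves dimethylamino as the only group of the four that stands apart. Nothing shown here gives a reason for that difference.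

Still open, from the compounds shown here alone, is whether a longer chain such as hexyl, a branched isopropyl or a chain ending in a carboxylic acid would stay in this range on the same nitrogen. A single methyl on that nitrogen would help show whether dimethylamino stands apart for its second methyl.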